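The source may hold more compounds than are shown below. What is called first, only, known or untested is meant among the compounds shown, and "the series" means these compounds.

Among the compounds with values here, in an ADME assay on microsomes from liver (Rattus norvegicus) for metabolic stability, read by LC-MS, with a stated time of 1 h, at 37 degrees C, tested at 4 uM (on this read-out lower numbers stand for a less stable compound and higher numbers for a more stable compound), compound 2 `O=C(O)c1cc(-c2cccc(COc3ccc4c(=O)n(C5CC5)sc4c3)c2)ccc1Cl` gives 86%, the highest of the two numbers so far. Its nearest neighbour is compound 1 `O=C(O)c1cc(-c2cccc(COc3ccc4c(=O)n(C5CCC5)sc4c3)c2)ccc1Cl`, which in this assay gives 67%; the two differ by one group, and a number 19 percentage points higher from compound 1 to compound 2 (beyond the scatter) lies beyond the scatter. For compound 3 `O=C1c2ccc(OCc3cccc(-c4ccc(C(F)(F)F)cc4F)c3)cc2CN1C1CCCC1` this assay reports "not determined" (no result reported), so no result is available for it.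

Compound 4 `CC(C)Cn1sc2cc(OCc3cccc(-c4ccc(Cl)c(C(=O)O)c4)c3)ccc2c1=O` differs from compound 2 in one place: isobutyl in place of cyclopropyl on an aromatic nitrogen. The cyclopropyl leaves and isobutyl enters, a chain of four carbon atoms with no ring, on the aromatic nitrogen of the five-membered ring next to the ring sulfur. Within the data shown here, the only measured step at that position is a number 19 percentage points higher from compound 1 to compound 2 (beyond the scatter), which moved in the direction of a smaller group. Among the measured compounds shown here, compound 4 goes the opposite way, towards a larger and open group, so a drop in this assay of at least that size is expected, though no isobutyl compound has been measured and the range is wide. For compound 4 the estimate is 55%, between 30% and 80%, an expected step of a number 31 percentage points lower from compound 2 to compound 4 (beyond the scatter).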

Compound 4, percent of the compound remaining: 86%
Estimate against measurement, compound 4: 31 percentage points below; measured number above the stated range.
By their numbers in this assay, from the lowest: compound 1; then compounds 2 and 4 (each within the scatter of the next).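

In this assay the change from cyclopropyl to isobutyl on the aromatic nitrogen gives no change at the digits printed from compound 2 to compound 4 (within the scatter) and so more heavy atoms at this position do not by themselves bring a lower number. Isobutyl in place of cyclobutyl gives a number 19 percentage points higher from compound 1 to compound 4 (beyond the scatter) and this leaves compound 1 alone at the low end of the three numbers, so the earlier step between the two rings does not extend into a simple trend with group size. Nothing in the data explains why compound 1 stands apart. Still open, going by these compounds, is whether a longer chain on the aromatic nitrogen, or an amine or a hydroxyl group carried on such a chain, would keep the number seen for compound 2 and compound 4. Also open, on these data alone, is whether a cyclopentyl group on the shared core would behave like cyclobutyl or like isobutyl.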